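The compounds below may be only part of what the source reports. "The series", "measured", "known", "first", "only" and "open" are said of these compounds alone.

Measured compounds:
Compound 1, `COc1ccc(/C=N/NC(=O)c2cnc3ccc(F)cc3c2N[C@@H](CSc2ccccc2)CC(=O)N(C)C)cc1`, gives "not determined" (no result reported) in an ADME assay on Vero cells (Chlorocebus sabaeus) for cytotoxicity, read by MTT assay, with a stated time of 72 h; on this read-out higher numbers stand for weaker inhibition and lower numbers for stronger inhibition.
Compound 2, `CN(C)C(=O)C[C@H](CSc1ccccc1)Nc1c(C(=O)N/N=C/c2ccc(F)cc2)cnc2ccc(F)cc12`, gives > 62.5 ug/mL in this assay.

The figure for compound 2 is a limit of this assay and not a number. Where compound 2 stands can therefore only be stated against that limit: the limit of > 62.5 ug/mL in this assay, at which 1 of the 2 values shown sits, and the entry for compound 1 holds no single number either. Compound 3, `CN(C)C(=O)C[C@H](CSc1ccccc1)Nc1c(C(=O)N/N=C/c2ccc(OC(F)(F)F)cc2)cnc2ccc(F)cc12`, has not yet been measured in this assay. It differs from compound 2 in one place: trifluoromethoxy in place of fluoro on an aromatic carbon. Among the compounds with values here, no step between two measured compounds is known here, so there is no measured precedent for the size of this change. The expectation for compound 3 is nothing beyond the scatter, with the step from compound 2 to compound 3 estimated as a step that the limit leaves unreadable from compound 2 to compound 3. Compound 3 is thus expected to give an estimated 70 ug/mL, within 30 ug/mL to 150 ug/mL, and the result may well again be reported only as a limit.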

Compound 3, half-maximal inhibitory concentration: > 62.5 ug/mL
Compound 3 gave a limit, no number (the forecaster's own chance of this, stated with the estimate: 70%); the middle value does not contradict the limit.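

In this assay compound 2 and compound 3 both give a limit and not a number, so no step can be read between them: the limit of > 62.5 ug/mL in this assay, at which 2 of the 3 values shown sit.

The compounds shown leave open whether trifluoromethoxy in place of fluoro on an aromatic carbon changes this read-out at all.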